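The source may hold more compounds than are shown below. What is called first, only, known or untested is meant among the compounds shown, and "the series" means these compounds.

Measured so far:
- compound 1 `O=C(Nc1cccc(-n2cc(-c3ccncc3)c(-c3ccc(Cl)c(O)c3)n2)c1)Nc1ccc(Cl)c(Cl)c1`: 4250 nM
- compound 2 `COc1cc(-c2nn(-c3cccc(NC(=O)c4ccc(Cl)c(C(F)(F)F)c4)c3)cc2-c2ccncc2)ccc1Cl`: > 32500 nM
- compound 3 `COc1cc(-c2nn(-c3cccc(NC(=O)c4cccc(C(F)(F)F)c4)c3)cc2-c2ccncc2)ccc1Cl`: 4560 nM

In a functional assay on MDA-MB-468 cells (Homo sapiens) for inhibition, read by sulforhodamine B assay, with a stated time of 48 h (on this read-out higher numbers stand for weaker inhibition of growth and lower numbers for stronger inhibition of growth), compound 2 gives only a limit, > 32500 nM, so no number is known for it; it sits at the limit of > 32500 nM in this assay, at which 1 of the 3 values shown sits. Compound 4 `COc1cc(-c2nn(-c3cccc(NC(=O)Nc4ccc(Cl)c(C(F)(F)F)c4)c3)cc2-c2ccncc2)ccc1Cl` is not yet measured. It differs from compound 2 in one place: (4-chloro-3-(trifluoromethyl)phenyl)amino in place of 4-chloro-3-(trifluoromethyl)phenyl on a carbonyl carbon. The amide of compound 2 thus becomes a urea in compound 4.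

Among the compounds with values here, the one measured step, an at least 7.1-fold lower number from compound 2 to compound 3 (0.85 log units; beyond the scatter), concerns a different change and does not bear on this one. Within the data shown here, no measured pair covers an amide turned into a urea. Compound 1 is a urea and differs from compound 4 in several places. In this assay, among the measured compounds shown here, compound 1 gives 4250 nM, which shows that a urea of this kind can be a number rather than a limit, but it offers no step to lean on.

Because compound 2 stands at the limit of > 32500 nM in this assay, at which 1 of the 3 values shown sits, the expected step of an at least 2.7-fold lower number from compound 2 to compound 4 (0.43 log units; beyond the scatter) cannot be fixed in size; a move towards a measurable number is expected, with wide uncertainty. Compound 4 is estimated at 12000 nM, within 3000 nM to 50000 nM.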

Compound 4, concentration for total growth inhibition: 4420 nM
Estimate against measurement, compound 4: 2.7-fold (0.43 log units) above, within the range that was stated.
By their numbers in this assay, from the lowest: compounds 1, 4 and 3 (each within the scatter of the next). At a limit, above all of these: compound 2.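

In this assay, turning the amide into a urea by adding an amino nitrogen on the carbonyl carbon, with the 4-chloro-3-(trifluoromethyl)phenyl group kept, gives an at least 7.3-fold lower number from compound 2 to compound 4 (0.86 log units; beyond the scatter). Compound 2 gives only a limit, so this step has a floor but no exact size: the limit of > 32500 nM in this assay, at which 1 of the 4 values shown sits. Measured against the amide without the chloro group, the urea shows a 1.0-fold lower number from compound 3 to compound 4 (0.01 log units; within the scatter), so the chloro group that goes with a limit in the amide compound 2 does not go with one in the urea compound 4.

The compounds shown leave open whether the added nitrogen itself matters or only the longer link, which a carbamate, with an oxygen in that place, or a methylene there could separate. Also open, as far as these compounds go, is how a urea carrying 3-(trifluoromethyl)phenyl, without the chloro group, would compare.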